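The compounds below may be only part of what the source reports. "The series", "measured", "known", "first", "only" and "open" are said of these compounds alone.

Measured so far:
Compound 1 `COc1cccc(C(=O)Nc2ccc(Cl)cc2CN2C(=O)c3ccccc3C2=O)c1` — in an assay on CHO cells for positive allosteric modulation of metabotropic glutamate receptor 5 (Rattus norvegicus), read by FLIPR (a higher number here means that more compound is needed for the effect, a lower number that less compound is needed), compound 1 gives < 1000 nM, a limit of the assay rather than a number.
Compound 2 `O=C(Nc1ccc(Br)cc1CN1C(=O)c2ccccc2C1=O)c1ccccn1` — in this assay compound 2 gives < 1000 nM, again a limit.
Compound 3 `O=C(Nc1ccc(Cl)cc1CN1C(=O)c2ccccc2C1=O)c1ccccc1[N+](=O)[O-]` — in this assay compound 3 gives < 1000 nM, also a limit.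

On the numbers shown, compound 3 cannot be placed relative to compound 1 or compound 2, since the limit of < 1000 nM in this assay, at which 3 of the 3 values shown sit, holds every value in the set. Among the measured compounds shown here, the single change within the measured compounds, a step that the two limits leave unreadable from compound 1 to compound 3, is not readable because the limit of < 1000 nM in this assay, at which 3 of the 3 values shown sit, covers both of its ends.

Compound 4 `O=C(Nc1ccc(Cl)cc1CN1C(=O)c2ccccc2C1=O)c1ccccc1` is not yet measured. Against compound 3 it shows (hydrogen in place of nitro on an aromatic carbon), ortho to a large group. For the measured compounds named here, no measured step touches this change, and the one step available gives no size at all. For this assay the step that the limit leaves unreadable from compound 3 to compound 4 is therefore expected to stay within the scatter, with compound 4 most likely reported again as a limit. Compound 4 is estimated at 400 nM in this assay, within a range from 100 nM to 1500 nM.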

Compound 4, half-maximal effective concentration: < 1000 nM
Compound 4 ended at the assay's limit (the forecaster's own chance of this, stated with the estimate: 60%); the middle value lies beyond the limit too.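

No step to compound 4, whether from compound 3 or from compound 1, can be read, because every value shown rests on one limit: the limit of < 1000 nM in this assay, at which 4 of the 4 values shown sit.

The compounds shown leave open whether nitro, methoxy and hydrogen on the aromatic ring differ at all in this assay.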